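The compounds below may be only part of what the source reports. "The series", "measured", "known", "first", "only" and "open" are said of these compounds alone.

In an assay on isolated protein for inhibition of Nitric oxide synthase, inducible (Homo sapiens), read by scintillation counting, with a stated time of 30 min, tested at 50 uM (on this read-out higher numbers stand for more inhibition at the one concentration tested (going by the name of the read-out) and lower numbers for less inhibition), compound 1 `CCCC(=O)N1N=C(c2cc(OC)ccc2N)SC1(C)C` gives 91.1%, and compound 2 `CCCCC(=O)N1N=C(c2cc(OC)ccc2N)SC1(C)C` gives 101%. The change between them is methyl in place of hydrogen on a saturated chain carbon, three bonds along the chain from a carbonyl carbon and it produced a step of a number 9.9 percentage points higher from compound 1 to compound 2 (within the scatter). Compound 3 `CCC(=O)N1N=C(c2cc(Cl)ccc2N)SC1(C)C` gives 1.07% in this assay, the lowest of the three numbers; the difference between its core and the core of compound 1 is not broken down here. Compound 4 `CCCC(=O)N1N=C(c2cc(Cl)ccc2N)SC1(C)C` has not been measured in this assay. It differs from compound 3 by methyl in place of hydrogen on a saturated chain carbon, two bonds along the chain from a carbonyl carbon. For the measured compounds named here, this is the same kind of change as the one from compound 1 to compound 2, but not the same: there the methyl enters three bonds along the chain from a carbonyl carbon, here two bonds along the chain from a carbonyl carbon. Since the earlier step of a number 9.9 percentage points higher from compound 1 to compound 2 (within the scatter) stayed within the scatter, the step from compound 3 to compound 4 is expected to be small as well, estimated at a number 3.9 percentage points higher from compound 3 to compound 4 (within the scatter). On that basis, compound 4 is expected to give about 5% in this assay, between 0% and 25%.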

Compound 4, a percentage reported as inhibition, at one concentration (the size of the read-out at that concentration, not a potency): 66.2%
Estimate against measurement, compound 4: 61.2 percentage points below; the whole stated range lies below it.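

In this assay, methyl in place of hydrogen on a saturated chain carbon, two bonds along the chain from a carbonyl carbon, gives a step of a number 65.1 percentage points higher from compound 3 to compound 4 (beyond the scatter). In this assay, methyl in place of hydrogen did not bring a step of the same size on the two cores: the same change on two cores in this assay, a number 9.9 percentage points higher (within the scatter) from compound 1 to compound 2 and a number 65.1 percentage points higher (beyond the scatter) from compound 3 to compound 4, 55.2 percentage points apart, beyond the scatter of two such steps. This shows that the small step on the core of compound 1 was a poor guide to the core of compound 3, but it does not separate the effect of the core from that of the place, since the methyl enters three bonds along the chain from a carbonyl carbon in one case and two bonds along in the other. With the chain unchanged, chloro in place of methoxy on an aromatic carbon gives a step of a number 24.9 percentage points lower from compound 1 to compound 4 (beyond the scatter), which is one pair only and sets no rule for the series.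

The compounds shown leave open whether a propanoyl chain on the core of compound 1 would give a number as low as compound 3 does, and how a longer chain would read on the core of compound 3. Other groups on that aromatic carbon, such as fluoro or a nitrile, also remain open.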